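The source may report more compounds than this note shows. Statements on the series, on what has been measured and on what is new or still open speak of the compounds shown alone.

Compound 2, `CC(C)C[C@H](N)c1cc(C(F)(F)F)ccc1N1CCN(C(=O)COc2ccc(Cl)cc2)CC1`, is the compound with the highest number among the three measured in an assay on HEK293 cells for displacement of a labelled ligand from Melanocortin receptor 4 (Homo sapiens) (a higher number here means a weaker inhibitor, a lower number a stronger inhibitor), where compound 2 gives 2900 nM. Compound 1, `CC(C)C[C@H](N)c1cc(F)ccc1N1CCN(C(=O)C(C)Cc2ccc(Cl)cc2)CC1`, gives 390 nM in this assay, and compound 3, `COc1cc(Cl)ccc1CC(C)C(=O)N1CCN(c2ccc(Cl)cc2[C@@H](N)CC(C)C)CC1`, gives 9.1 nM; both of these gaps to compound 2 lie beyond the usual scatter.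

Compound 4, `COc1ccc(CC(C)C(=O)N2CCN(c3ccc(C(F)(F)F)cc3[C@@H](N)CC(C)C)CC2)cc1F`, differs from compound 2 in the group carried on the carbonyl carbon whose other neighbour is the amide-type nitrogen in a ring: 1-(3-fluoro-4-methoxybenzyl)ethyl in place of (4-chlorophenoxy)methyl on a carbonyl carbon

Among the compounds with values here, no single-change step between measured compounds is available for this exact exchange, so the expectation rests on what the three values show. Compound 3, which carries a 2-methyl-3-arylpropanoyl amide bearing a methoxy substituent, gives 9.1 nM, far below the number of compound 2, and compound 1 with a related amide gives 390 nM. On that basis compound 4 is expected to move well beyond the scatter toward a lower number, a step estimated as a 73-fold lower number from compound 2 to compound 4 (1.86 log units; beyond the scatter). The estimate for compound 4 in this assay is 40 nM, with a range from 10 nM to 160 nM.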

Compound 4, inhibition constant: 200 nM
The estimate for compound 4 lay 5.0-fold (0.70 log units) below the measured number; the measured number lies above the stated range.
By their numbers in this assay, from the lowest: compound 3; then compounds 4 and 1 (each within the scatter of the next); then compound 2.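

Read in this assay, the step of a 15-fold lower number from compound 2 to compound 4 (1.16 log units; beyond the scatter) is the first comparison in which only the group on the carbonyl carbon changes, so this position alone is shown to carry a large effect on the number. The two groups have the same counts of hydrogen-bond donors and acceptors and of six-membered aromatic rings, and neither carries a net charge, so the step arises without any change in these counts. No measurement shown here accounts for the step.

The compounds shown leave open which feature of 1-(3-fluoro-4-methoxybenzyl)ethyl matters, since the chain, the ring substituents and the heavy-atom count all change together. Also open, as far as these compounds go, is how this position would respond to a group such as a carboxylic acid or an amine on the aromatic ring.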